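This account rests on a few compounds, and the source may have more. Where it says the series, first, only, none or still open, it means among the compounds named here.

Compound 1 `CCO/C(O)=C1\C(COCCn2ccnc2C)=NC(C)=C(C(=O)OC)C1c1ccccc1Cl` gives 2.51 nM in a functional assay (aorta) with Rattus norvegicus as the target (a lower number here means a stronger inhibitor, a higher number a weaker inhibitor), the lowest of the three numbers measured there. Compound 2 `CCO/C(O)=C1\C(COCCn2cnc3ccccc32)=NC(C)=C(C(=O)OC)C1c1ccccc1Cl` gives 20 nM in this assay, and compound 3 `CCO/C(O)=C1\C(COCCN2C(=O)CNC2=O)=NC(C)=C(C(=O)OC)C1c1ccccc1Cl` gives 31.6 nM. The move to compound 4 `CCO/C(O)=C1\C(COCCN2CC(=O)N(C)C2=O)=NC(C)=C(C(=O)OC)C1c1ccccc1Cl` is 3-methyl-2,4-dioxoimidazolidin-1-yl in place of 2-methyl-1H-imidazol-1-yl on a saturated chain carbon, two bonds along the chain from an oxygen on a saturated carbon. Among the compounds with values here, two measured steps bear on it: an 8.0-fold higher number from compound 1 to compound 2 (0.90 log units; beyond the scatter) and a 13-fold higher number from compound 1 to compound 3 (1.10 log units; beyond the scatter), both toward weaker inhibition, while a 1.6-fold higher number from compound 2 to compound 3 (0.20 log units; within the scatter) stays within the scatter. Within the data shown here, the ring entering in compound 4 most resembles the one present in compound 3, so given a 13-fold higher number from compound 1 to compound 3 (1.10 log units; beyond the scatter) the expected step is a weakening of similar size, a 12-fold higher number from compound 1 to compound 4 (1.08 log units; beyond the scatter). Compound 4 is therefore estimated at 30 nM in this assay, with a range from 10 nM to 90 nM.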

Compound 4, half-maximal inhibitory concentration: 25.1 nM
Beside the measured number, compound 4's estimate is 1.2-fold (0.08 log units) above it, and the stated range covers the measured number.
By their numbers in this assay, from the lowest: compound 1; then compounds 2, 4 and 3 (each within the scatter of the next).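

In this assay, 3-methyl-2,4-dioxoimidazolidin-1-yl also gives a weaker inhibitor than 2-methyl-1H-imidazol-1-yl, with a 10-fold higher number from compound 1 to compound 4 (1.00 log units; beyond the scatter), so a third replacement on this saturated chain carbon falls short of compound 1. It joins the other two replacements: a 1.3-fold lower number from compound 3 to compound 4 (0.10 log units; within the scatter) and a 1.3-fold higher number from compound 2 to compound 4 (0.10 log units; within the scatter) both stay within the scatter, so these three groups cannot be told apart here. Nothing available explains the gap to compound 1. Going by these compounds, it remains open whether that advantage belongs to the 2-methyl-1H-imidazol-1-yl ring alone, and how a plain 1H-imidazol-1-yl, an amine such as morpholine, or a longer chain would stand.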